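A Chlorine Swap on a Weak Cytotoxic Scaffold

The source may hold more compounds than are shown below. What is called first, only, known or untested is meant among the compounds shown, and "the series" means these compounds.

Within the data shown here, compound 1, with the structure `C=CCn1c(=O)/c(=C\c2cccc(C)c2)[nH]c(=O)/c1=C\c1ccccc1OC`, is the one member of this small set that gives a measurable number. In a functional assay on MCF7 cells (Homo sapiens) for cytotoxicity, read by CCK-8 assay, with a stated time of 72 h (on this read-out higher numbers stand for weaker inhibition and lower numbers for stronger inhibition), compound 1 gives 20700 nM, which places it as the only quantified entry among three tested compounds. Compound 2, `C=CCn1c(=O)/c(=C\c2ccc(F)c(Br)c2)[nH]c(=O)/c1=C\c1ccccc1OC`, carries a different substituted phenyl group and gives "not active" (no number reported) in this assay. Compound 3, `COc1ccccc1/C=c1/[nH]c(=O)/c(=C\c2cccc(Cl)c2Cl)[nH]c1=O`, lacks the allyl chain and gives "not active" (no number reported) in this assay. Among the measured compounds shown here, neither of those two results is a number, so no step between measured compounds can be computed here.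

Compound 4, `C=CCn1c(=O)/c(=C\c2ccccc2Cl)[nH]c(=O)/c1=C\c1ccccc1OC`, differs from compound 1 by a single change: 2-chlorophenyl in place of 3-methylphenyl on a double-bonded chain carbon bound to an aromatic carbon. With compound 1 already weak and the two other entries reporting no activity at all, the expectation is that a chlorinated phenyl group will not make compound 4 stronger, and may well push it out of the measurable range. Compound 4 is expected to give about 35000 nM, with a plausible range from 12000 nM to 100000 nM. That estimate means an expected step of a 1.7-fold higher number from compound 1 to compound 4 (0.23 log units; within the scatter), in the direction of weaker inhibition.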

Compound 4, half-maximal inhibitory concentration: 4700 nM
Compound 4: middle estimate off by 7.4-fold (0.87 log units), on the high side; the whole stated range lies above it.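

In this assay, the change to 2-chlorophenyl gives a 4.4-fold lower number from compound 1 to compound 4 (0.64 log units; beyond the scatter), so this place on the shared core responds to what the phenyl ring carries, and the step lies beyond the usual scatter. Compound 4 also shows that a halogen on this ring does not by itself end measurable activity, while compound 2, whose ring carries bromine and fluorine, reports no number, and steps to entries without numbers cannot be read. Nothing measured here explains the stronger result, so its reason remains unknown.

From the compounds shown here alone, it remains open how a plain phenyl, a 3-chlorophenyl or a 2-aminophenyl group would read at this place, and so whether gaining the chlorine or losing the methyl matters more. Going by these compounds, how a propyl chain in place of the allyl chain would affect compound 4 is likewise open.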